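Swapping 3-fluorophenyl for 4-chlorophenyl: what to expect

The source may report more compounds than this note shows. Statements on the series, on what has been measured and on what is new or still open speak of the compounds shown alone.

Measured in a functional assay on M21 cells (Homo sapiens) for antiproliferative activity, read by sulforhodamine B assay, with a stated time of 48 h; on this read-out higher numbers stand for weaker inhibition and lower numbers for stronger inhibition:
- Compound 1 `CN1CCN(c2ccc(S(=O)(=O)Oc3c(Cl)cc(Cl)cc3Cl)cc2)C1=O`: 1700 nM
- Compound 2 `CN1CCN(c2ccc(S(=O)(=O)Oc3cccc(F)c3)cc2)C1=O`: 5800 nM
- Compound 3 `CN1CCN(c2ccc(S(=O)(=O)Oc3cccc([N+](=O)[O-])c3)cc2)C1=O`: 23000 nM

Compound 2 holds the middle place among these three numbers. Compound 1 gives a lower number and compound 3 a higher one, and both gaps lie beyond the scatter of repeated measurements.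

The next compound is compound 4 `CN1CCN(c2ccc(S(=O)(=O)Oc3ccc(Cl)cc3)cc2)C1=O`, which is compound 2 with one change: 4-chlorophenyl in place of 3-fluorophenyl on an oxygen. In words, 4-chlorophenyl sits in place of 3-fluorophenyl on an oxygen.

Going by the values given here, only one measured step changes a single group, a 4.0-fold higher number from compound 2 to compound 3 (0.60 log units; beyond the scatter). It gives a rough idea of how far one group on this ring can move the number, but it swaps in a different group, so it cannot set the direction here. Among the compounds with values here, a weak hint comes from compound 1, the only measured compound carrying chlorine, at 1700 nM. That compound differs from compound 2 in more than one place, so the hint stays weak.

A small shift toward a lower number is therefore expected, perhaps no larger than the scatter. The estimated change is a 1.7-fold lower number from compound 2 to compound 4 (0.22 log units; within the scatter). Compound 4 is expected at 3500 nM, within an estimated range of 1300 nM to 9000 nM.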

Compound 4, half-maximal inhibitory concentration: 43000 nM
Beside the measured number, compound 4's estimate is 12-fold (1.09 log units) below it; measured number above the stated range.
By their numbers in this assay, from the lowest: compound 1; then compound 2; then compounds 3 and 4 (each within the scatter of the next).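

In this assay, the step of a 7.4-fold higher number from compound 2 to compound 4 (0.87 log units; beyond the scatter) shows that the aryl group on this oxygen, whose other neighbour is the sulfonyl sulfur, is sensitive to even a modest swap: the number moves beyond the scatter although the heavy-atom count, the hydrogen-bond donor and acceptor counts and the net charge all stay the same. The single chlorine of 4-chlorophenyl does not bring a lower number here, and both one-place changes away from 3-fluorophenyl now point the same way, this one and the earlier 4.0-fold higher number from compound 2 to compound 3 (0.60 log units; beyond the scatter), so 3-fluorophenyl gives the lowest number of the three groups compared directly. No measured information is available to explain this rise.

This swap changes both the halogen and its place on the ring, so the compounds shown cannot separate the contribution of either change. Also open, on these data alone, is how the number would respond to an amine, a carboxylic acid or a methoxy group on this ring, or to a plain phenyl group with no substituent at all.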